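Chlorophenyl urea in a thienopyrimidine-thiadiazole series

The compounds below may be only part of what the source reports. "The series", "measured", "known", "first", "only" and "open" are said of these compounds alone.

Compound 1 `Cc1cccc(NC(=O)Nc2nnc(Sc3ncnc4scc(-c5ccncc5)c34)s2)c1` and compound 2 `O=C(Nc1ccc(Cl)c(Cl)c1)Nc1nnc(Sc2ncnc3scc(-c4ccncc4)c23)s1` share a core and differ only in the aryl group on the urea nitrogen. In a functional assay on HepG2 cells (Homo sapiens) for antiproliferative activity, read by MTT assay, with a stated time of 48 h (a higher number here means a weaker inhibitor, a lower number a stronger inhibitor), compound 1 gives 20700 nM, the lowest of the two numbers shown, and in this assay compound 2 gives 61900 nM. Going by the values given here, the step of a 3.0-fold higher number from compound 1 to compound 2 (0.48 log units; beyond the scatter) is the only measured step available.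

Compound 3 `O=C(Nc1ccc(Cl)cc1)Nc1nnc(Sc2ncnc3scc(-c4ccncc4)c23)s1` is not yet measured in this assay. It differs from compound 1 as follows: 4-chlorophenyl in place of 3-methylphenyl on an amide-type nitrogen. The step from compound 1 to compound 2 bears on this change, since it also replaces 3-methylphenyl with a chlorine-bearing phenyl on the same nitrogen, and it raised the number modestly, beyond the scatter. Compound 3 carries 4-chlorophenyl rather than the 3,4-dichlorophenyl of compound 2, so a smaller rise than that step is expected, possibly one that stays within the scatter. Compound 3 is therefore expected to show a step of a 1.7-fold higher number from compound 1 to compound 3 (0.23 log units; within the scatter) in this assay. The estimate for compound 3 in this assay is 35000 nM, with a range from 15000 nM to 80000 nM.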

Compound 3, half-maximal inhibitory concentration: 28900 nM
The estimate for compound 3 lay 1.2-fold (0.08 log units) above the measured number, within the range that was stated.
By their numbers in this assay, from the lowest: compounds 1 and 3 (each within the scatter of the next); then compound 2.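

In this assay, the swap of 3-methylphenyl for 4-chlorophenyl on the amide-type nitrogen gives a 1.4-fold higher number from compound 1 to compound 3 (0.14 log units; within the scatter) and so leaves the two compounds indistinguishable, which shows that this position accepts a single chlorine-bearing phenyl in place of the methyl-bearing one without a readable change. The difference between 3,4-dichlorophenyl and 4-chlorophenyl, read as a 2.1-fold lower number from compound 2 to compound 3 (0.33 log units; beyond the scatter) with hydrogen in place of chloro on an aromatic carbon, is modest but beyond the scatter, so the weaker reading of compound 2 goes with the extra chloro rather than with the presence of chlorine on this phenyl ring as such. Nothing available explains why the extra chloro carries this step or why the methyl and chloro groups read alike.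

The compounds shown leave open whether 3-chlorophenyl alone would follow compound 2 or compound 3, and how a methoxy group or an amine on this ring, or a cyclohexyl group in place of it, would read. All three numbers also remain high and close together, so they show only a narrow part of what this position can do.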